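Cytotoxicity of a nitroimidazooxazine series on Vero cells

The source may report more compounds than this note shows. Statements on the series, on what has been measured and on what is new or still open speak of the compounds shown alone.

Three compounds share one core and differ only in the group that hangs from it. Compound 1 `C[C@]1(CN2CCc3oc(-c4ccc(F)cc4)nc3C2)Cn2cc([N+](=O)[O-])nc2O1` carries a fluorophenyl-bearing side ring, compound 2 `C[C@]1(CN2CCn3cc(-c4ccc(F)c(F)c4)nc3C2)Cn2cc([N+](=O)[O-])nc2O1` a difluorophenyl-bearing one, and compound 3 `C[C@]1(CN2CCc3nc(C(F)(F)F)ccc3C2)Cn2cc([N+](=O)[O-])nc2O1` a trifluoromethyl on a ring of the bicyclic side piece. All three were meant to be read in an ADME assay on Vero cells (Chlorocebus sabaeus) for cytotoxicity, read by MTT assay, with a stated time of 72 h; on this read-out lower numbers stand for higher toxicity in this test and higher numbers for lower toxicity in this test.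

For compound 1 the result in this assay is a limit of the test rather than a number: compound 1 gives > 32 ug/mL. Compound 2 in this assay is recorded as "not determined" (no result reported). Compound 3 in this assay likewise has "not determined" (no result reported), so no single number stands for it. Of the other two entries, one is empty. The other is the limit noted above (the limit of > 32 ug/mL in this assay, at which 1 of the 3 values shown sits).

Compound 4 `C[C@]1(CN2CCc3nc(-c4cc(F)ccc4Cl)ccc3C2)Cn2cc([N+](=O)[O-])nc2O1` is the compound still to be measured. It differs from compound 3 by one exchange (2-chloro-5-fluorophenyl in place of trifluoromethyl on an aromatic carbon). Within the data shown here, with no measured step to lean on, no change beyond the scatter is expected in this assay, in either direction. Compound 4 is expected in this assay to give about 40 ug/mL, within a range from 15 ug/mL to 120 ug/mL.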

Compound 4, half-maximal cytotoxic concentration: > 32 ug/mL
Compound 4 gave a limit, no number; the forecaster's own chance of this, stated with the estimate: 65%; the middle value lies beyond the limit too.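

In this assay compound 4 gives > 32 ug/mL, which is a limit of the test and not a number. Among these compounds, compound 3 has no number to set against it, so no step from compound 3 to compound 4 can be read. The same limit now recurs in the series: the limit of > 32 ug/mL in this assay, at which 2 of the 4 values shown sit.

The compounds shown leave open whether any of these side groups changes toxicity on these cells.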